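A few compounds are considered here, and "the series" means these few. Any claim that something is new, unique, unknown or untested is made for them only; others in the source may bear on it.

In a functional assay on KB cells (Homo sapiens) for inhibition, read by MTT assay, with a stated time of 24 h, tested at 10 ug/mL (a higher number here means more inhibition of growth at the concentration tested, a lower number less inhibition of growth), three compounds have been measured so far. Compound 1, `O=C(CCCCC(S)CCS)Nc1ccc([N+](=O)[O-])c(C(F)(F)F)c1`, gives 4.04%. Compound 2, `CC(=O)SCCC(CCCCC(=O)Nc1ccccc1)SC(C)=O`, gives 2.5%. Compound 3, `CC(=O)SCCC(CCCCC(=O)Nc1ccccc1Cl)SC(C)=O`, gives 6.55%, which places it within the scatter of both other compounds, so the three cannot be separated on these numbers.

Compound 4, `CC(=O)SCCC(CCCCC(=O)Nc1ccc(Cl)cc1)SC(C)=O`, has not yet been measured. It has the same atoms as compound 3, joined differently: 4-chlorophenyl in place of 2-chlorophenyl on an amide-type nitrogen. This places 4-chlorophenyl in place of 2-chlorophenyl on an amide-type nitrogen.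

Among the compounds with values here, only one measured step bears on this change: a number 4.1 percentage points higher from compound 2 to compound 3 (within the scatter), which puts chloro in place of hydrogen on an aromatic carbon. That step stays within the scatter. Within the data shown here, it shows what introducing the chloro group does in one position, but no measured pair compares two chlorophenyl isomers, so the evidence for this change is indirect. Among the measured compounds shown here, with so small a step as the only guide, no shift beyond the scatter is expected in this assay, in either direction. The estimated change is a number 0.6 percentage points lower from compound 3 to compound 4 (within the scatter). For compound 4, the expected value is 6%, with an estimated range from 1% to 15%.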

Compound 4, percent growth inhibition at one concentration: 18.1%
Compound 4: middle estimate off by 12.1 percentage points, on the low side; measured number above the stated range.
By their numbers in this assay, from the lowest: compounds 2, 1 and 3 (each within the scatter of the next); then compound 4.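

In this assay, the two chlorophenyl isomers can now be told apart: 4-chlorophenyl in place of 2-chlorophenyl on an amide-type nitrogen gives a number 11.6 percentage points higher from compound 3 to compound 4 (beyond the scatter), although the two compounds have the same atoms. The earlier compounds shown here showed only that chloro in place of hydrogen on an aromatic carbon stayed within the scatter, as a number 4.1 percentage points higher from compound 2 to compound 3 (within the scatter), whereas the same kind of replacement now gives a number 15.6 percentage points higher from compound 2 to compound 4 (beyond the scatter), so what chloro does depends on where it sits on the phenyl group. Nothing measured here explains why the two isomers differ.

As far as these compounds go, with only these two chlorophenyl isomers, it remains open whether the 4-chlorophenyl result is particular to chloro or would also appear with a bromophenyl or a methoxyphenyl group on the same amide-type nitrogen. From the compounds shown here alone, it is also open whether the 4-chlorophenyl group would keep its advantage over 2-chlorophenyl if free thiol groups, as in compound 1, stood in place of the acetylthio groups of compound 3 and compound 4.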